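Fluoro for hydrogen on the anilide ring in HepG2 toxicity

A few compounds are considered here, and "the series" means these few. Any claim that something is new, unique, unknown or untested is made for them only; others in the source may bear on it.

Measured compounds:
compound 1, `CSc1ccc2nc(C)cc(OCC(=O)Nc3cc(C)cc(C)c3)c2c1`: in a toxicity assay on HepG2 cells (Homo sapiens) for inhibition, read by CellTiter-Glo, with a stated time of 48 h (on this read-out lower numbers stand for stronger inhibition and higher numbers for weaker inhibition), compound 1 gives > 100000 nM
compound 2, `COc1ccc2nc(C)cc(OCc3ccc4ccccc4n3)c2c1`: in this assay compound 2 gives 31600 nM
compound 3, `COc1ccc2nc(C)cc(OCC(=O)Nc3ccccc3)c2c1`: in this assay compound 3 gives 39800 nM

The value for compound 1 is a limit of the assay and not a number (the limit of > 100000 nM in this assay, at which 1 of the 3 values shown sits). Among the two numbers, compound 3 stands highest in this assay, but its nearest neighbour, compound 2, sits within the usual scatter of it, so the two cannot be told apart on these data.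

The step followed here leads from compound 3 to compound 4, `COc1ccc2nc(C)cc(OCC(=O)Nc3ccc(F)cc3)c2c1`, which has yet to be measured in this assay. The two differ in one place: fluoro in place of hydrogen on an aromatic carbon. Among the compounds with values here, no measured pair of this kind is available here to show what such a change does in this assay, so the step can only be judged from the structural change itself and from the narrow spread of the numbers seen so far.

Compound 4 is therefore expected to stay close to compound 3, with a step of a 1.0-fold higher number from compound 3 to compound 4 (0.00 log units; within the scatter) that is expected to lie within the scatter. The estimate for compound 4 in this assay is 40000 nM, within a range from 15000 nM to 100000 nM.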

Compound 4, half-maximal inhibitory concentration: 63100 nM
Compound 4: middle estimate off by 1.6-fold (0.20 log units), on the low side, within the range that was stated.
By their numbers in this assay, from the lowest: compounds 2, 3 and 4 (each within the scatter of the next). At a limit, above all of these: compound 1.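

Within the data shown here, the change from phenyl to 4-fluorophenyl supplies the first pair in this assay that differs in one place, and the step reads a 1.6-fold higher number from compound 3 to compound 4 (0.20 log units; within the scatter) and so gives no measured sign that this position responds to fluoro in place of hydrogen. Among these compounds, what the earlier compounds could only suggest from their narrow spread now rests on a direct comparison: on this aromatic carbon, para to a large group, the two compounds cannot be told apart, though a single pair speaks for this one change at this one place and not for the ring as a whole. Compound 1 alone gives a limit of the assay and not a number: the limit of > 100000 nM in this assay, at which 1 of the 4 values shown sits.

Still open, from the compounds shown here alone, is whether a larger group at this same position, such as chloro, methoxy or trifluoromethyl, would stay equally close to compound 3, or whether an amine or a carboxylic acid there would move the number beyond the scatter. The compounds shown also leave open what fluoro would do at any other place on this ring or on the shared core.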